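Removing the amide group from compound 2

A few compounds are considered here, and "the series" means these few. Any claim that something is new, unique, unknown or untested is made for them only; others in the source may bear on it.

Measured in a physicochemical assay for lipophilicity, at pH 7.4; on this read-out higher numbers stand for higher lipophilicity and lower numbers for lower lipophilicity:
compound 1 `CNC(=O)c1cc(C(=O)N[C@H]2[C@@H]3C[C@@H](O)C[C@@H]32)cc2c1OC[C@H]2c1ccccc1`: 2.9
compound 2 `CCC(=O)N1C[C@@H]2[C@H](C1)[C@H]2NC(=O)c1cc(C(=O)NC)c2c(c1)[C@H](c1ccccc1)CO2`: 3.4

Of these two compounds, compound 2 has the higher number, at 3.4, and the gap to compound 1 lies beyond the scatter. The next compound, compound 3 `CNC(=O)c1cc(C(N)=O)cc2c1OC[C@H]2c1ccccc1`, carries this change relative to compound 2: a hydrogen atom in place of a group of 10 heavy atoms (8 carbon, 1 nitrogen, 1 oxygen; one three-membered non-aromatic ring of carbon only, one five-membered non-aromatic ring with 1 hetero atom), on an amide-type nitrogen.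

Going by the values given here, only one measured step bears on this change: a number 0.50 log units higher from compound 1 to compound 2 (beyond the scatter). That modest step exchanged one group on the same amide-type nitrogen for a group of 10 heavy atoms, and the number rose. Compound 3 has no such group at all, so a downward step larger than that one is expected, although a single step is thin evidence. The expected step is a number 1.20 log units lower from compound 2 to compound 3 (beyond the scatter). Compound 3 is estimated at 2.2, with an expected range from 1.6 to 2.8.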

Compound 3, distribution coefficient: 2.7
Beside the measured number, compound 3's estimate is 0.50 log units below it, within the range that was stated.
By their numbers in this assay, from the lowest: compounds 3 and 1 (each within the scatter of the next); then compound 2.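

On this amide-type nitrogen, a hydrogen atom in place of the group of 10 heavy atoms gives a number 0.70 log units lower from compound 2 to compound 3 (beyond the scatter) in this assay and so shows that removing the whole group takes the number back down. A hydrogen atom in place of the smaller group of 7 heavy atoms gives a number 0.20 log units lower from compound 1 to compound 3 (within the scatter) and so shows that these two cannot be told apart here, while only the group of 10 heavy atoms stands clear of both. No measurement shown explains why these groups read as they do.

As far as these compounds go, it remains open whether a simple ethyl group or a longer chain on this nitrogen would read like the hydrogen atom or like the group of 10 heavy atoms. From the compounds shown here alone, how a group carrying an amine or a carboxylic acid would read at this position also remains open.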